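A few compounds are considered here, and "the series" means these few. Any claim that something is new, unique, unknown or untested is made for them only; others in the source may bear on it.

Measured compounds:
Compound 1, `COc1ccc(/C=C2\SC(N[C@H](C(=O)NS(=O)(=O)c3ccc(C)cc3)C(C)C)=NC2=O)cc1`: 12.8 ug/mL
Compound 2, `Cc1ccc(S(=O)(=O)NC(=O)[C@H](CC(C)C)NC2=NC(=O)/C(=C/c3ccccc3F)S2)cc1`: 16.4 ug/mL

The two measured compounds share a core and differ in the aryl group on the double-bonded chain carbon and in the amino acid side chain. In a functional assay on HepG2 cells (Homo sapiens) for antiproliferative activity, read by MTT assay, with a stated time of 48 h (a lower number here means a stronger inhibitor, a higher number a weaker inhibitor), compound 2 gives 16.4 ug/mL, the higher of the two numbers, while in this assay compound 1 gives 12.8 ug/mL; the gap between them is within the scatter, so the two values tell no difference in strength.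

Compound 3, `Cc1ccc(S(=O)(=O)NC(=O)[C@H](CC(C)C)NC2=NC(=O)/C(=C/c3cccc(Cl)c3)S2)cc1`, has not been measured. It differs from compound 2 in one place: 3-chlorophenyl in place of 2-fluorophenyl on a double-bonded chain carbon bound to a double-bonded ring carbon. Within the data shown here, no pair of measured compounds shows a step for such a halogen swap on the aryl group, so there is nothing to anchor its size. The expectation for this assay is a step of a 1.2-fold lower number from compound 2 to compound 3 (0.07 log units; within the scatter) from compound 2 to compound 3, which amounts to no change beyond the scatter in either direction. Compound 3 is therefore estimated at 14 ug/mL, between 6 ug/mL and 35 ug/mL.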

Compound 3, half-maximal inhibitory concentration: 16.5 ug/mL
Beside the measured number, compound 3's estimate is 1.2-fold (0.07 log units) below it, within the range that was stated.
By their numbers in this assay, from the lowest: compounds 1, 2 and 3 (each within the scatter of the next).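

In this assay, the halogen swap on the aryl group gives a step of a 1.0-fold higher number from compound 2 to compound 3 (0.00 log units; within the scatter). Among these compounds, this is the first pair of measured compounds to differ in this one place, whereas compound 1 and compound 2 differ in two places and could not isolate the aryl group, so 2-fluorophenyl and 3-chlorophenyl on this side chain cannot be told apart in this assay. Nothing available here bears on why the two groups read alike.

The pair alters both the halogen and its ring place at once, so 2-chlorophenyl or 3-fluorophenyl would be needed to separate the two. It also leaves open how an unsubstituted phenyl, or an aryl group carrying an amine or a carboxylic acid, would read at this place.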